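Branching the urea substituent: propyl to isopropyl

The compounds below may be only part of what the source reports. "The series", "measured", "known", "first", "only" and "open" are said of these compounds alone.

Compound 2 `CCCNC(=O)N1CCC(NS(=O)(=O)c2ccc(NC(=O)c3ccccc3C)c3ccccc23)CC1` stands lowest of the two numbers measured in an assay on L1.2 cells for binding affinity to C-C chemokine receptor type 8 (Homo sapiens) (a higher number here means a weaker inhibitor, a lower number a stronger inhibitor), where compound 2 gives 77.4 nM. For the measured compounds named here, its only measured neighbour is compound 1 `Cc1ccccc1C(=O)Nc1ccc(S(=O)(=O)NC2CCN(C(N)=O)CC2)c2ccccc12`, which in this assay gives 243 nM; the step of a 3.1-fold lower number from compound 1 to compound 2 (0.50 log units; beyond the scatter) came from the single change of propyl in place of hydrogen on the amide-type nitrogen. Compound 3 `Cc1ccccc1C(=O)Nc1ccc(S(=O)(=O)NC2CCN(C(=O)NC(C)C)CC2)c2ccccc12` keeps every atom of compound 2 and differs only in how they are joined: isopropyl in place of propyl on an amide-type nitrogen. Going by the values given here, no measured step bears directly on this rearrangement; the one step known concerns adding the chain, not branching it. With nothing added or removed, the change from compound 2 to compound 3 is expected to stay within the scatter, a 1.0-fold higher number from compound 2 to compound 3 (0.01 log units; within the scatter). Compound 3 is therefore estimated at 80 nM in this assay, within a range from 35 nM to 190 nM.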

Compound 3, inhibition constant: 77.7 nM
Beside the measured number, compound 3's estimate is 1.0-fold (0.01 log units) above it; low and high end bracket the measured number.
By their numbers in this assay, from the lowest: compounds 2 and 3 (each within the scatter of the next); then compound 1.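

In this assay, moving from the straight chain to the branched one on this amide-type nitrogen leaves the number unchanged within the scatter, with a 1.0-fold higher number from compound 2 to compound 3 (0.00 log units; within the scatter) as the step, so the two chains cannot be told apart here. The gain over hydrogen at this position therefore does not depend on the chain being straight: a 3.1-fold lower number from compound 1 to compound 3 (0.50 log units; beyond the scatter) is a step that reads the same as a 3.1-fold lower number from compound 1 to compound 2 (0.50 log units; beyond the scatter) for propyl. Nothing available explains why the two chains read alike.

On these data alone, whether a longer chain such as butyl, a ring such as cyclopropyl or phenyl, or a chain ending in an amine or a carboxylic acid would lower the number further at this nitrogen remains open. So does whether propyl and isopropyl would still read alike with a different group in place of the 2-methylbenzoyl amide.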